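Swapping the bromophenyl group of compound 3

The source may hold more compounds than are shown below. What is called first, only, known or untested is meant among the compounds shown, and "the series" means these compounds.

- compound 1 `Cc1cc(=O)c2c(O)c(CN(C)CC(=O)O)c(O)c([C@H]3CCN(C)C[C@H]3O)c2o1` gives 23% growth inhibition
- compound 2 `Cc1cc(=O)c2c(O)c(CN3CCC(c4ccccc4)CC3)c(O)c([C@H]3CCN(C)C[C@H]3O)c2o1` gives 26% growth inhibition
- compound 3 `Cc1oc2c([C@H]3CCN(C)C[C@H]3O)c(O)cc(O)c2c(=O)c1C(O)c1ccc(F)c(Br)c1` gives 25% growth inhibition

In a functional assay on HL-60 cells (Homo sapiens) for inhibition, read by MTT assay, with a stated time of 48 h, tested at 10 uM (a lower number here means less inhibition of growth, a higher number more inhibition of growth at the concentration tested), compound 3 at 25% lies within the scatter of both compound 1 and compound 2, so the three values show no order. Compound 4 `CCOc1ccc(Br)c(C(O)c2c(C)oc3c([C@H]4CCN(C)C[C@H]4O)c(O)cc(O)c3c2=O)c1` has not yet been measured. It has 2-bromo-5-ethoxyphenyl in place of 3-bromo-4-fluorophenyl on a saturated chain carbon bound to an aromatic carbon and an oxygen on a saturated carbon. For the measured compounds named here, no measured pair shows this change alone. The expected size of a number 1 percentage points higher from compound 3 to compound 4 (within the scatter) in this assay is none beyond the scatter, with no direction favoured. Compound 4 is estimated at 26% with an expected range from 12% to 42% in this measurement.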

Compound 4, percent growth inhibition at one concentration: 2%
Compound 4: middle estimate off by 24 percentage points, on the high side; measured number outside the range, below it.
By their numbers in this assay, from the lowest: compound 4; then compounds 1, 3 and 2 (each within the scatter of the next).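

In this assay the aryl group on the saturated chain carbon makes a difference: 2-bromo-5-ethoxyphenyl in place of 3-bromo-4-fluorophenyl gives a number 23 percentage points lower from compound 3 to compound 4 (beyond the scatter). The earlier compounds shown here, all within the scatter of one another, showed no such separation. Nothing measured here explains this step.

The two aryl groups differ in both the bromine placement and the second substituent, so the compounds shown cannot separate these parts. As far as these compounds go, how a nitrile or a longer alkoxy chain on the phenyl ring would read at this position remains open.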